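Series notes: aryl swap on the shared core, lipophilicity

A few compounds are considered here, and "the series" means these few. Any claim that something is new, unique, unknown or untested is made for them only; others in the source may bear on it.

Three compounds of the series have a number in a physicochemical assay for lipophilicity, using the shake flask method, in phosphate buffer, measured as octanol-water partition, with a stated time of 30 min, at pH 7.4; a lower number here means a more polar compound, a higher number a more lipophilic compound. Compound 1 `Cc1cc(-c2cnc(NCc3c(F)ccc4c3CCO4)c3cn[nH]c(=O)c23)n(C)n1` gives 3 in this assay. Compound 2 `COCCC(=O)Nc1cnc(NCc2c(F)ccc3c2CCO3)n2cnnc12` gives 1.4 in this assay, and compound 3 `O=C1Oc2ccccc2CN1c1cnc(NCc2c(F)ccc3c2CCO3)n2cnnc12` gives 2.7 in this assay. Among these three numbers compound 1 stands highest; its gap to compound 3 lies within the scatter, so no order between these two can be read, while its gap to compound 2 is clearly beyond the scatter, compound 2 being the more polar of the pair. Going by the values given here, no two of the measured compounds differ in one place only, so no single-change step within the measured set is available.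

Compound 4 `Cc1ncccc1-c1cnc(NCc2c(F)ccc3c2CCO3)c2cn[nH]c(=O)c12` is the next compound to be measured in this assay. It differs from compound 1 in one place: 2-methylpyridin-3-yl in place of 1,3-dimethyl-1H-pyrazol-5-yl on an aromatic carbon. Both the group that leaves and the group that enters carry no charge and the same count of heavy atoms, the difference being one ring size and the acceptor count. On that basis a small step is expected, at most at the edge of the scatter, with no clear direction forced by the measured compounds; a slight rise is the working guess. Compound 4 is estimated to give 3.2 in this assay, between 2.7 and 3.7, so that the expected step of a number 0.20 log units higher from compound 1 to compound 4 (within the scatter) stays within the scatter.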

Compound 4, distribution coefficient: 3
Compound 4: middle estimate off by 0.20 log units, on the high side; low and high end bracket the measured number.
By their numbers in this assay, from the lowest: compound 2; then compounds 3, 1 and 4 (each within the scatter of the next).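

In this assay, 2-methylpyridin-3-yl in place of 1,3-dimethyl-1H-pyrazol-5-yl on an aromatic carbon of the shared core gives no change at the digits printed from compound 1 to compound 4 (within the scatter). Going by these compounds alone, this is the first single-change step, and the earlier compounds offered no direct reading at this position. Here, one six-membered aromatic ring with 1 hetero atom and one five-membered aromatic ring with 2 hetero atoms, both with 7 heavy atoms and no net charge, can be exchanged with no readable separation in this read-out, despite the differences in ring size and acceptor count. Nothing at hand gives a reason for this outcome.

Within the data shown here, the step covers only this one pair of methyl-bearing aromatic rings, so it cannot show whether the same holds for other aromatic groups at this position, such as an unsubstituted phenyl ring. It also leaves open how far the number would move with a group of a different kind on the same carbon, such as a carboxylic acid, a dimethylaminomethyl group or a longer alkoxy chain.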